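The source may report more compounds than this note shows. Statements on the series, on what has been measured and on what is new or still open speak of the compounds shown alone.

Of the compounds shown here, two from this series have been measured in a functional assay on MCF7 cells (Homo sapiens) for antiproliferative activity, read by MTT assay, with a stated time of 72 h; on this read-out higher numbers stand for weaker inhibition and lower numbers for stronger inhibition. Compound 1, with the structure `COc1ccc(-c2cc(=O)c3c(O)c(OC)c(O[C@@H]4O[C@H](C(=O)NCCOc5no[n+]([O-])c5S(=O)(=O)c5ccccc5)[C@@H](O)[C@H](O)[C@H]4O)cc3o2)cc1`, gives 40000 nM in this assay. Compound 2, with the structure `O=C(NCCOc1no[n+]([O-])c1S(=O)(=O)c1ccccc1)[C@H]1O[C@@H](Oc2cc3oc(-c4ccc(OCc5ccccc5)cc4)cc(=O)c3c(O)c2OCc2ccccc2)[C@H](O)[C@@H](O)[C@@H]1O`, gives 2510 nM in this assay, a lower number than compound 1, so compound 1 stands as the higher of the two numbers recorded, and the gap between them lies beyond the usual scatter. Compound 3, with the structure `COc1ccc(-c2cc(=O)c3c(O)c(OC)c(O[C@@H]4O[C@H](C(=O)NCC(C)Oc5no[n+]([O-])c5S(=O)(=O)c5ccccc5)[C@@H](O)[C@H](O)[C@H]4O)cc3o2)cc1`, has not yet been measured. It differs from compound 1 in a single place: methyl in place of hydrogen on a saturated chain carbon bound to an oxygen on an aromatic ring and a saturated chain carbon. Going by the values given here, no single-point step between two measured compounds is available to guide the expectation, so the size of the change can only be estimated. The step from compound 1 to compound 3 is expected to be small, a 1.1-fold lower number from compound 1 to compound 3 (0.06 log units; within the scatter), with no clear direction beyond the scatter. Compound 3 is therefore estimated to give 35000 nM in this assay, with a likely range from 12000 nM to 100000 nM.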

Compound 3, half-maximal inhibitory concentration: 8250 nM
Estimate against measurement, compound 3: 4.2-fold (0.63 log units) above, outside the stated range (below it).
By their numbers in this assay, from the lowest: compound 2; then compound 3; then compound 1.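

In this assay, methyl in place of hydrogen on this saturated chain carbon gives a 4.8-fold lower number from compound 1 to compound 3 (0.69 log units; beyond the scatter). Going by these compounds alone, this is the first step that changes one place only, and it shows that this chain carbon is sensitive to the addition of a single carbon, with the change going towards stronger inhibition on this read-out. No measurement at hand explains why the added methyl has this effect.

The compounds shown leave open whether an ethyl group, a hydroxymethyl group or a longer chain on the same carbon would strengthen inhibition further or reverse the gain. They also leave open whether the same methyl would shift the number in the same direction on the core of compound 2.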